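Taking Away the Acetamido Group: What to Expect

The source may hold more compounds than are shown below. What is called first, only, known or untested is meant among the compounds shown, and "the series" means these compounds.

Of the compounds shown here, two have been measured in a functional assay on HT-1080 cells (Homo sapiens), read by transwell migration, with a stated time of 24 h, tested at 1 uM; on this read-out lower numbers stand for a stronger effect and higher numbers for a weaker effect at the one concentration tested. Compound 1 `O=C(Oc1cccc(Cl)c1)c1cc2cc(CCl)ccc2oc1=O` gives 79.8%, while compound 2 `CC(=O)NCc1ccc2oc(=O)c(C(=O)Oc3cccc(Cl)c3)cc2c1` gives 36.6%. Among the compounds with values here, the one measured step, acetamido in place of chloro on a saturated chain carbon bound to an aromatic carbon, produced a number 43.2 percentage points lower from compound 1 to compound 2 (beyond the scatter). Among these two numbers compound 2 stands at the lower, stronger end.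

Compound 3 `Cc1ccc2oc(=O)c(C(=O)Oc3cccc(Cl)c3)cc2c1` has not yet been measured. It differs from compound 2 by hydrogen in place of acetamido on a saturated chain carbon bound to an aromatic carbon. Within the data shown here, no measured step removes a group from this carbon outright; the single step from compound 1 to compound 2 shows only that what sits on that carbon can move the read-out a great deal. For compound 3 a step of a number 28.4 percentage points higher from compound 2 to compound 3 (beyond the scatter) is expected, because a number 43.2 percentage points lower from compound 1 to compound 2 (beyond the scatter) went together with the very acetamido that is now gone. Compound 3 is therefore estimated at 65%, within a range from 40% to 90%.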

Compound 3, a percentage reported as activity, at one concentration (the size of the read-out at that concentration, not a potency): 52.5%
Beside the measured number, compound 3's estimate is 12.5 percentage points above it; the range from low to high includes it.
By their numbers in this assay, from the lowest: compound 2; then compound 3; then compound 1.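

In this assay, hydrogen in place of acetamido on this carbon gives a number 15.9 percentage points higher from compound 2 to compound 3 (beyond the scatter) and so the acetamido does count for something of its own: the low number of compound 2 is not merely the loss of chloro. Hydrogen in place of chloro gives a number 27.3 percentage points lower from compound 1 to compound 3 (beyond the scatter) and this shows that removing chloro already accounts for part of the earlier drop. The plain methyl of compound 3 thus sits in the middle, with chloro on this carbon going with a higher number and acetamido with a lower one.

Nothing shown bears on why these groups differ in this way. Also open, from the compounds shown here alone, is how an amine, a carboxylic acid or a longer chain on this carbon would compare with acetamido.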